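The source may report more compounds than this note shows. Statements on the series, on what has been measured and on what is new or still open speak of the compounds shown alone.

Series notes. Compound 1 `Cc1ccc(C(=O)c2nc(NCc3ccccn3)nc3ccsc23)s1` and compound 2 `Cc1ccc(C(=O)c2nc(NC(C)c3ccccn3)nc3ccsc23)s1` share one core; compound 2 differs from compound 1 by methyl in place of hydrogen on a saturated chain carbon bound to an aromatic carbon and a nitrogen on an aromatic ring. In a functional assay on CHO-K1 cells for antagonist activity at adenosine receptor A2b (Homo sapiens), read by FLIPR and calcium flux (on this read-out higher numbers stand for weaker inhibition and lower numbers for stronger inhibition), compound 1 gives 43 nM, and compound 2 gives 19 nM, which is a 2.3-fold lower number from compound 1 to compound 2 (0.35 log units; beyond the scatter). Compound 3 `CCNC(=O)c1nc(NCc2cccnc2)nc2ccsc12` rests on a different core, and the difference between the two cores is not broken down here. In this assay compound 3 gives 120 nM, the highest of the three numbers, beyond the scatter from both others. Compound 4 `CC(C)NC(=O)c1nc(NCc2cccnc2)nc2ccsc12` is not yet measured; it differs from compound 3 by methyl in place of hydrogen on a saturated chain carbon bound to an amide-type nitrogen and a saturated chain carbon. This is the same kind of change as that from compound 1 to compound 2 but not the same: there the place was a saturated chain carbon bound to an aromatic carbon and a nitrogen on an aromatic ring, here it is a saturated chain carbon bound to an amide-type nitrogen and a saturated chain carbon. Because a 2.3-fold lower number from compound 1 to compound 2 (0.35 log units; beyond the scatter) is the only measured case of this kind of change and sits at a different place, the step from compound 3 to compound 4 in this assay is expected to be smaller, near a 1.3-fold lower number from compound 3 to compound 4 (0.12 log units; within the scatter). Starting from compound 3 at 120 nM, compound 4 is expected to come in near 90 nM, between 40 nM and 250 nM.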

Compound 4, half-maximal inhibitory concentration: 309 nM
Compound 4: middle estimate off by 3.4-fold (0.54 log units), on the low side, outside the stated range (above it).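

In this assay, going from ethylcarbamoyl to isopropylcarbamoyl gives a 2.6-fold higher number from compound 3 to compound 4 (0.41 log units; beyond the scatter), so this methyl raises the number, whereas the earlier methyl lowered it. Methyl in place of hydrogen therefore does not carry over from one core to the other as a single step of fixed direction, and the two measured cases disagree: the same change on two cores in this assay, a 2.3-fold lower number (0.35 log units; beyond the scatter) from compound 1 to compound 2 and a 2.6-fold higher number (0.41 log units; beyond the scatter) from compound 3 to compound 4, 5.8-fold (0.77 log units) apart, beyond the scatter of two such steps This does not show whether the core or the place of the methyl sets the outcome, since the two pairs differ in both, and two pairs give no rule for any further core.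

Still open, going by these compounds, is whether methyl on the saturated chain carbon bound to an aromatic carbon would lower the number on the core of compound 3 as it does on the core of compound 1, which would separate place from core. Also open, on these data alone, is how a longer chain, such as propyl or butyl, in place of the ethyl of compound 3 would read in this assay.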